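The source may report more compounds than this note shows. Statements on the series, on what has been measured and on what is new or still open speak of the compounds shown alone.

Measured in a functional assay on FaDu cells (Homo sapiens) for cytotoxicity, read by MTT assay, with a stated time of 72 h; a lower number here means that less compound is tolerated, a higher number that more compound is tolerated:
- compound 1 `COc1ccc(NC(=O)C(=O)c2cn(C(C)C)c3ccccc23)cn1` gives 85 nM
- compound 2 `COc1ccc(NC(=O)C(=O)c2cn(CC3CCO3)c3ccccc23)cn1` gives 686 nM
- compound 3 `COc1ccc(NC(=O)C(=O)c2cn(CC(C)C)c3ccccc23)cn1` gives 317 nM

Compound 3 stands second highest of the three numbers, with compound 1 lower and compound 2 higher, and both gaps lie beyond the scatter.

The next compound is compound 4 `COc1ccc(NC(=O)C(=O)c2cn(CCOC(C)C)c3ccccc23)cn1`. It has isopropoxymethyl in place of isopropyl on a saturated chain carbon bound to an aromatic nitrogen. Cut one bond further out, the same difference reads isobutyl to 2-isopropoxyethyl.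

The nearest measured change is at the same place: a 2.2-fold lower number from compound 2 to compound 3 (0.34 log units; beyond the scatter), with isopropyl in place of oxetan-2-yl. Within the data shown here, compound 2 is the only measured compound whose chain also holds an oxygen, and it has the highest number. The other two steps, a 3.7-fold higher number from compound 1 to compound 3 (0.57 log units; beyond the scatter) and an 8.1-fold higher number from compound 1 to compound 2 (0.91 log units; beyond the scatter), show that changes on the aromatic nitrogen have moved the number beyond the scatter, upward from compound 1 in both cases. Among the measured compounds shown here, no measured compound carries an open-chain ether, so the comparison is loose.

A modest upward step is therefore expected in this assay, close in size to the step between compound 2 and compound 3. The expected step is a 2.2-fold higher number from compound 3 to compound 4 (0.34 log units; beyond the scatter). For compound 4 the estimate is 700 nM, with an expected range of 250 nM to 1900 nM.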

Compound 4, concentration lethal to 50% of the cells: 211 nM
Compound 4: middle estimate off by 3.3-fold (0.52 log units), on the high side; the whole stated range lies above it.
By their numbers in this assay, from the lowest: compound 1; then compounds 4 and 3 (each within the scatter of the next); then compound 2.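

In this assay, the open-chain ether on the aromatic nitrogen gives a 1.5-fold lower number from compound 3 to compound 4 (0.18 log units; within the scatter), so 2-isopropoxyethyl and isobutyl cannot be told apart here, and the oxygen in this chain does not carry the number up to the level of compound 2. The earlier compounds shown here held oxygen only in the oxetan-2-yl of compound 2, and the new comparison separates the two oxygen-bearing chains, with a 3.3-fold lower number from compound 2 to compound 4 (0.51 log units; beyond the scatter); the high number of compound 2 therefore cannot be read as a general result for an ether oxygen in this chain. Isopropyl directly on the aromatic nitrogen keeps the lowest number of the series, with a 2.5-fold higher number from compound 1 to compound 4 (0.39 log units; beyond the scatter), and no measurement is available that explains any of these steps.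

Cyclobutylmethyl on the aromatic nitrogen would be the direct test of whether the ring or its oxygen goes with the number of compound 2. On these data alone, a longer open-chain ether, or a chain ending in an amine or a carboxylic acid, remains open at this position, as does whether these steps hold on any core other than the shared one.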